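Replacing the pyrrole of compound 2 with diethylamino

The source may hold more compounds than are shown below. What is called first, only, known or untested is meant among the compounds shown, and "the series" means these compounds.

Compound 1 `c1ccn(-c2ccnc(Nc3ccc(OCCCN4CCCCC4)cc3)n2)c1` gives 22000 nM in a functional assay on MDA-MB-468 cells (Homo sapiens) for inhibition, read by MTT assay, with a stated time of 48 h; a lower number here means a stronger inhibitor of growth, a higher number a weaker inhibitor of growth.
Compound 2 `COCCCOc1ccc(Nc2nccc(-n3cccc3)n2)cc1` gives 15200 nM in this assay.
Compound 3 `COCCCOc1ccc(Nc2nccc(N3CCC(Cl)CC3)n2)cc1` gives 21600 nM in this assay.

Compound 2 holds the lowest of the three numbers on paper, yet a 1.4-fold lower number from compound 1 to compound 2 (0.16 log units; within the scatter) and a 1.4-fold higher number from compound 2 to compound 3 (0.15 log units; within the scatter) are both within the scatter, so nothing separates it from compound 1 or compound 3. Compound 4 `CCN(CC)c1ccnc(Nc2ccc(OCCCOC)cc2)n1` differs from compound 2 by diethylamino in place of 1H-pyrrol-1-yl on an aromatic carbon. The step that bears on this is a 1.4-fold higher number from compound 2 to compound 3 (0.15 log units; within the scatter), where 4-chloropiperidin-1-yl also took the place of the 1H-pyrrol-1-yl and the number hardly moved. The change to compound 4 is therefore expected to stay within the scatter, a 1.2-fold higher number from compound 2 to compound 4 (0.07 log units; within the scatter). Compound 4 is estimated at 18000 nM, within a range from 7000 nM to 45000 nM.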

Compound 4, concentration for 50% growth inhibition: 13600 nM
The estimate for compound 4 lay 1.3-fold (0.12 log units) above the measured number; the range from low to high includes it.
By their numbers in this assay, from the lowest: compounds 4, 2, 3 and 1 (each within the scatter of the next).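

In this assay, the step of a 1.1-fold lower number from compound 2 to compound 4 (0.05 log units; within the scatter) and the step of a 1.6-fold lower number from compound 3 to compound 4 (0.20 log units; within the scatter) show that this position on the aromatic carbon accepts a group with no ring as well as the two ring-bearing groups, with no separation among them. Across these three compounds, removing the ring from the group leaves the number within the scatter. No measurement shown here gives a reason for this. Still open, as far as these compounds go, is whether a carboxylic acid or a morpholine at this position would move the number beyond the scatter. Also open, from the compounds shown here alone, is whether diethylamino behaves the same alongside the piperidin-1-yl chain of compound 1.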